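The source may hold more compounds than are shown below. What is called first, only, known or untested is meant among the compounds shown, and "the series" means these compounds.

In an ADME assay on microsomes from liver (Rattus norvegicus) for metabolic stability (a higher number here means that the compound lasts longer, a lower number that the compound disappears faster), compound 3 `Nc1nc(NCCNc2ncc(-c3ncc[nH]3)c(-c3ccc(C(F)(F)F)cc3)n2)ccc1[N+](=O)[O-]` gives > 0.5 h, which is a limit and not a number. Compound 1 `N#Cc1ccc(-c2nc(NCCNc3ccc([N+](=O)[O-])c(N)n3)ncc2-c2ncc[nH]2)cc1` gives > 0.5 h, also a limit. Compound 2 `Clc1ccc(-c2nc(NCCNc3ccccn3)ncc2-c2ncc[nH]2)c(Cl)c1` gives > 0.5 h, again a limit. The next change leads to compound 4 `Nc1nc(NCCNc2ncc(-c3ncc[nH]3)c(-c3ccc(F)cc3F)n2)ccc1[N+](=O)[O-]`, with 2,4-difluorophenyl in place of 4-(trifluoromethyl)phenyl (2,4-difluorophenyl in place of 4-(trifluoromethyl)phenyl on an aromatic carbon). This group sits on an aromatic carbon, ortho to a 1H-imidazol-2-yl group. Going by the values given here, the one measured step that bears on it, a step that the two limits leave unreadable from compound 1 to compound 3, gives no size to carry over, since the data hold only (the limit of > 0.5 h in this assay, at which 3 of the 3 values shown sit). No shift beyond the scatter is therefore expected, in either direction, and the estimated step is a step that the limit leaves unreadable from compound 3 to compound 4. Compound 4 is estimated at 0.8 h, with an expected range of 0.4 h to 1.6 h.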

Compound 4, half-life: > 0.5 h
Compound 4 was reported as a limit (the forecaster's own chance of this, stated with the estimate: 75%); the middle value lies beyond the limit too.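

Going by these compounds alone, compound 4, like compound 1 and compound 3, is reported only as a limit, so no step between them can be read: the limit of > 0.5 h in this assay, at which 4 of the 4 values shown sit. As far as these compounds go, how long each compound actually lasts in this assay, and whether the exchanged groups make any difference, stays open.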